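The compounds below may be only part of what the source reports. "The series", "measured", "known", "first", "only" and "open" are said of these compounds alone.

The compounds here share one core, carrying a nitrile and two phenyl groups, and differ only in the group on one carbon of the five-membered ring. Compound 1 `COc1cccc(-c2c(-c3ccccc3)c(-c3ccccc3)n3ccc(C#N)cc23)c1` carries a 3-methoxyphenyl group there, compound 2 `N#Cc1ccn2c(-c3ccccc3)c(-c3ccccc3)c(Cc3ccccc3)c2c1` a benzyl group, and compound 3 `COc1ccccc1-c1c(-c2ccccc2)c(-c2ccccc2)n2ccc(C#N)cc12` a 2-methoxyphenyl group. In an assay for inhibition of Polyunsaturated fatty acid lipoxygenase ALOX15 (Oryctolagus cuniculus) (a higher number here means a weaker inhibitor, a lower number a stronger inhibitor), compound 2 gives 46000 nM, a weak result. For compound 1 the outcome in this assay is "not determined" (no result reported). Compound 3 likewise has no number: in this assay its result is "not determined" (no result reported), so where it stands cannot be said from the data at hand, and it is one of two compounds in this set without a single value.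

Compound 4 `N#Cc1ccn2c(-c3ccccc3)c(-c3ccccc3)c(CO)c2c1` is the next point of interest. Compared with compound 3 it differs in one place: hydroxymethyl in place of 2-methoxyphenyl on an aromatic carbon. Compound 3 has no number. Among the compounds with values here, no step from compound 3 to compound 4 can be sized, and neither direction nor magnitude can be drawn from that pair. Within the data shown here, the only anchor is compound 2, which gives 46000 nM with a benzyl group in the same position; compound 4 swaps that kind of group for a small hydroxymethyl group.

Compound 4 is therefore expected, with wide uncertainty, to be a weak inhibitor in this assay, estimated at 60000 nM within a range of 15000 nM to 250000 nM.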

Compound 4, half-maximal inhibitory concentration: 34000 nM
Estimate against measurement, compound 4: 1.8-fold (0.25 log units) above; measured number inside the range.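

Swapping the phenyl at the end of the benzyl group for hydroxy gives a 1.4-fold lower number from compound 2 to compound 4 (0.13 log units; within the scatter) in this assay, so on this carbon of the five-membered ring, the two groups cannot be told apart. Within the data shown here, this is the first readable comparison at this position: removing that aromatic ring and bringing in a hydrogen-bond donor leaves both compounds weak inhibitors, with no change beyond the usual scatter. The steps involving compound 3 cannot be read, as it has no number, and nothing in the data at hand explains why this exchange leaves the read-out within the scatter.

The compounds shown leave open whether any group on this carbon can give a clearly stronger or weaker inhibitor, since the only two numbers available sit within the scatter of each other. Going by these compounds, an amine, a carboxylic acid or a longer chain in this place could test that, while the standing of the 2-methoxyphenyl and 3-methoxyphenyl groups of compound 3 and compound 1 stays unknown.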